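This account rests on a few compounds, and the source may have more. Where it says the series, first, only, none or still open, it means among the compounds named here.

In an ADME assay on HEp-2 cells (Homo sapiens) for cytotoxicity, read by CCK-8 assay, with a stated time of 6 days (a lower number here means that less compound is tolerated, a higher number that more compound is tolerated), compound 1 `Cc1ccn2c(CCCCO)c(Cn3c(=O)n(C4CC4)c4ccncc43)nc2c1` reaches only the limit > 100000 nM. Compound 2 `O=C(O)/C=C/c1c(Cn2c(=O)n(C3CC3)c3ccncc32)nc2cc(Cl)ccn12` likewise gives only the limit > 100000 nM in this assay. For the measured compounds named here, the two values shown thus sit at the limit of > 100000 nM in this assay, at which 2 of the 2 values shown sit; compound 2 stands there with a limit and no number, and no step between measured compounds exists to set a scale. Compound 3 `O=c1n(Cc2nc3cc(Cl)ccn3c2NC2CCCCC2)c2cnccc2n1C1CC1` differs from compound 2 by cyclohexylamino in place of 2-carboxyethenyl on an aromatic carbon. The expected step of an at least 1.6-fold lower number from compound 2 to compound 3 (0.22 log units; that floor lies within the scatter) in this assay is downward but probably not beyond the scatter. Compound 3 is therefore estimated at 60000 nM, in the range 20000 nM to 150000 nM.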

Compound 3, half-maximal cytotoxic concentration: > 100000 nM
Compound 3 was reported as a limit (the forecaster's own chance of this, stated with the estimate: 50%); middle value at least 1.6-fold (0.22 log units) from the limit.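

No step from compound 2 to compound 3 can be read in this assay, because both values are limits: the limit of > 100000 nM in this assay, at which 3 of the 3 values shown sit.

The compounds shown leave open where any of them would reach half-maximal cytotoxicity, and whether cyclohexylamino in place of 2-carboxyethenyl alters it.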